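Trifluoromethyl on the cinnamamide aryl of the chloro series

The compounds below may be only part of what the source reports. "The series", "measured", "known", "first", "only" and "open" are said of these compounds alone.

Three compounds of the series carry a number in a functional assay on NIH3T3 cells for agonist activity at Urotensin-2 receptor (Homo sapiens), with a stated time of 5 days; on this read-out higher numbers stand for an effect only at larger amounts of compound and lower numbers for an effect already at smaller amounts. Compound 1 `CN(C)CCC(NC(=O)/C=C/c1ccc(C(F)(F)F)cc1)c1ccc2ccccc2c1` gives 135 nM. Compound 2 `CN(C)CCC(NC(=O)CCc1ccccc1)c1ccc(Cl)cc1` gives 1660 nM, and compound 3 `CN(C)CCC(NC(=O)/C=C/c1ccccc1)c1ccc(Cl)cc1` gives 427 nM, the second highest number of the three, between compound 1 and compound 2. Within the data shown here, the one step within the measured set, a 3.9-fold lower number from compound 2 to compound 3 (0.59 log units; beyond the scatter), concerns the linker to the carbonyl and does not touch the aryl ring that is changed next.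

Compound 4 `CN(C)CCC(NC(=O)/C=C/c1ccc(C(F)(F)F)cc1)c1ccc(Cl)cc1` differs from compound 3 by trifluoromethyl in place of hydrogen on an aromatic carbon. Among the measured compounds shown here, no measured pair isolates this change: compound 1 carries the same trifluoromethyl but also a different core, so its value and that of compound 3 bracket two changes at once and only show that the trifluoromethyl-bearing compound sits lower. A modest lowering is therefore expected rather than a large one, with the step of a 1.9-fold lower number from compound 3 to compound 4 (0.29 log units; within the scatter) taken as the estimate. Compound 4 is expected at about 220 nM, within 70 nM to 650 nM.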

Compound 4, half-maximal effective concentration: 129 nM
Estimate against measurement, compound 4: 1.7-fold (0.23 log units) above; low and high end bracket the measured number.
By their numbers in this assay, from the lowest: compounds 4 and 1 (each within the scatter of the next); then compound 3; then compound 2.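

In this assay, trifluoromethyl in place of hydrogen on the aromatic carbon para to a large group now has a measured pair of its own: a 3.3-fold lower number from compound 3 to compound 4 (0.52 log units; beyond the scatter) and so this single change reaches beyond the scatter. With trifluoromethyl held on the cinnamamide aryl, the other listed change, 4-chlorophenyl in place of naphthalen-2-yl, gives a 1.0-fold lower number from compound 1 to compound 4 (0.02 log units; within the scatter) and so stays within the scatter, which separates the two changes that the comparison of compound 1 with compound 3 had mixed. No measurement at hand accounts for the effect of the trifluoromethyl group.

On these data alone, it remains open whether a nitrile, a methoxy group or a carboxylic acid at the same place would match trifluoromethyl. Also open, as far as these compounds go, is whether the trifluoromethyl step carries over to the saturated linker of compound 2 or to the core of compound 1.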